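A Fluorine Added to the Fused Ring of Compound 1

The source may hold more compounds than are shown below. What is called first, only, known or untested is meant among the compounds shown, and "the series" means these compounds.

Three measured compounds share one core and differ in the group on the carbonyl carbon. Compound 1 `COc1cc(OC)cc(C(=O)NC2CCN(Cc3ccc4ccccc4c3)CC2)c1` carries 3,5-dimethoxyphenyl there; in an assay on isolated protein for binding affinity to melanin-concentrating hormone receptor 1 (Homo sapiens) (on this read-out higher numbers stand for weaker inhibition and lower numbers for stronger inhibition), compound 1 gives 27 nM. Compound 2 `O=C(NC1CCN(Cc2ccc3ccccc3c2)CC1)c1ccc(F)cc1` differs from it by 3,5-dimethoxyphenyl in place of 4-fluorophenyl on a carbonyl carbon, and in this assay compound 2 gives 36 nM. Compound 3 `O=C(NC1CCN(Cc2ccc3ccccc3c2)CC1)c1ccc(F)c(F)c1` gives 18 nM in this assay. The change from compound 2 to compound 3 is fluoro in place of hydrogen on an aromatic carbon, and it made a step of a 2.0-fold lower number from compound 2 to compound 3 (0.30 log units; within the scatter). The other steps, a 1.3-fold higher number from compound 1 to compound 2 (0.12 log units; within the scatter) and a 1.5-fold lower number from compound 1 to compound 3 (0.18 log units; within the scatter), are also small.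

Compound 4 `COc1cc(OC)cc(C(=O)NC2CCN(Cc3ccc4cc(F)ccc4c3)CC2)c1` is not yet measured. It comes from compound 1 by fluoro in place of hydrogen on an aromatic carbon. This is the same kind of change as from compound 2 to compound 3, yet the place differs: there it was ortho to a fluoro group and meta to a large group, here it is part of a fused or bridged system of two rings, meta to a fused ring and para to a fused ring. The expected step from compound 1 to compound 4 in this assay is a 1.2-fold lower number from compound 1 to compound 4 (0.09 log units; within the scatter), resting on the small step of a 2.0-fold lower number from compound 2 to compound 3 (0.30 log units; within the scatter). Compound 4 is estimated to give 22 nM in this assay, expected between 8 nM and 60 nM.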

Compound 4, inhibition constant: 32 nM
The estimate for compound 4 lay 1.5-fold (0.16 log units) below the measured number, within the range that was stated.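

In this assay, within the data shown here, putting fluoro in place of hydrogen on the fused ring of compound 1 gave a 1.2-fold higher number from compound 1 to compound 4 (0.07 log units; within the scatter), so this change produced no step that stands clear of the usual scatter. Set beside the earlier case, the two steps differ by no more than repeated measurements could account for: the same change on two cores in this assay, a 2.0-fold lower number (0.30 log units; within the scatter) from compound 2 to compound 3 and a 1.2-fold higher number (0.07 log units; within the scatter) from compound 1 to compound 4, 2.4-fold (0.37 log units) apart, within the scatter of two such steps. Among these compounds, this gives no sign that the change behaves differently on the two cores, but it does not prove that it carries over: only two small steps are at hand, the fluoro stands at a different place in each, and a modest real difference could stay hidden within the scatter.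

The compounds shown leave open whether fluoro on another carbon of the fused ring, or a chloro or nitrile on this same carbon, would give a step beyond the scatter. They also leave open what an amine or a carboxylic acid on the phenyl ring attached to the carbonyl would do.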